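Chain shortening on the shared core, propanamide series

The compounds below may be only part of what the source reports. "The series", "measured", "known", "first", "only" and "open" are said of these compounds alone.

Measured so far:
compound 1 `CCC(=O)NCCC1CCc2ccccc2N1Cc1ccccc1` — in a functional assay on CHO cells with melatonin receptor type 1A (Homo sapiens) as the target, read by GTPgammaS binding, with a stated time of 1 h; a lower number here means a smaller maximal response, a higher number a larger maximal response "not determined" (no result reported)
compound 2 `CCNC(=S)NCC1CCc2ccccc2N1` — 35%

Compound 1 `CCC(=O)NCCC1CCc2ccccc2N1Cc1ccccc1` carries a 2-(propanoylamino)ethyl chain on its saturated ring carbon, but in this assay compound 1 gives "not determined" (no result reported), so it stands nowhere on the scale yet. For the measured compounds named here, the only measured point is compound 2 `CCNC(=S)NCC1CCc2ccccc2N1`, which in this assay gives 35%; it differs from both compound 1 and compound 3 in more than one place, so it gives orientation only.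

Compound 3 `CCC(=O)NCC1CCc2ccccc2N1Cc1ccccc1` is compound 1 with the chain cut by one carbon: propanoylamino in place of (propanoylamino)methyl on a saturated chain carbon bound to a saturated ring carbon.

Going by the values given here, with no measured step in this direction, a shift of one chain carbon is expected to move the largest response in this assay by a modest amount at most, with no direction that can be called beyond the scatter on the present data.

The largest response of compound 3 in this assay is therefore estimated at 40%, within 10% to 80%.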

Compound 3, largest response reached (Emax), in percent of the reference or control that the assay uses: 42%
Estimate against measurement, compound 3: 2 percentage points below, within the range that was stated.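

In this assay compound 1 gives "not determined" (no result reported) and compound 3 gives 42% so no step can be read between them. The compounds shown leave open how the change from 2-(propanoylamino)ethyl to (propanoylamino)methyl affects the largest response. No evidence bears on this result.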